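The source may report more compounds than this note shows. Statements on the series, on what has been measured and on what is new or still open speak of the compounds shown alone.

Compound 1 `c1ccc(CNCCCCN(C[C@H]2Cc3ccccc3CN2)[C@H]2CCCc3cccnc32)cc1` gives 20.1 nM in a functional assay on cells for antagonist activity at C-X-C chemokine receptor type 4 (Homo sapiens), read by fluorescence and calcium flux, with stated times of 25 min and 90 s; a higher number here means a weaker inhibitor, a lower number a stronger inhibitor. Compound 2 `c1ccc2c(c1)CN[C@@H](CN(CCCCNC1CCOCC1)[C@H]1CCCc3cccnc31)C2` gives 29.4 nM in this assay. Compound 3 `CC(C)(CCN)CN(C[C@H]1Cc2ccccc2CN1)[C@H]1CCCc2cccnc21` gives > 33300 nM in this assay, which is a limit of the assay and not a number.

Compound 3 therefore stands at the limit among the three measured compounds (the limit of > 33300 nM in this assay, at which 1 of the 3 values shown sits), while compound 1 and compound 2 sit within the scatter of each other: a 1.5-fold higher number from compound 1 to compound 2 (0.17 log units; within the scatter). Compound 4 `C(=C/CN(C[C@H]1Cc2ccccc2CN1)[C@H]1CCCc2cccnc21)\CNCc1ccccn1` has not been measured in this assay. It differs from compound 3 at one place: a group of 11 heavy atoms (9 carbon, 2 nitrogen; one six-membered aromatic ring with 1 hetero atom) in place of a group of 6 heavy atoms (5 carbon, 1 nitrogen; no ring), on a saturated chain carbon bound to an amine nitrogen.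

Going by the values given here, the steps that bear on this change run the other way. From compound 1 to compound 3, a ring-bearing group on the same chain carbon was replaced by the chain without a ring: an at least 1600-fold higher number from compound 1 to compound 3 (3.21 log units; beyond the scatter). From compound 2 to compound 3: an at least 1100-fold higher number from compound 2 to compound 3 (3.05 log units; beyond the scatter). Compound 4 restores a ring-bearing group of similar size to that of compound 1 at that place, so a large step downward is expected: an at least 1100-fold lower number from compound 3 to compound 4 (3.04 log units; beyond the scatter). Compound 4 is expected at about 30 nM, with a range from 8 nM to 150 nM.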

Compound 4, half-maximal inhibitory concentration: 58.3 nM
The estimate for compound 4 lay 1.9-fold (0.29 log units) below the measured number; the range from low to high includes it.
By their numbers in this assay, from the lowest: compounds 1, 2 and 4 (each within the scatter of the next, the first and the last beyond it). At a limit, above all of these: compound 3.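

In this assay, a ring-bearing group of a different kind, with a six-membered aromatic ring with 1 hetero atom and 1 double bond outside aromatic rings, also works on the saturated chain carbon bound to an amine nitrogen: an at least 570-fold lower number from compound 3 to compound 4 (2.75 log units; beyond the scatter). Compound 3 remains a limit of the assay and not a number, so the size of that step is only a bound: the limit of > 33300 nM in this assay, at which 1 of the 4 values shown sits. The ring-bearing groups do not all match, since a 2.9-fold higher number from compound 1 to compound 4 (0.46 log units; beyond the scatter), whereas a 2.0-fold higher number from compound 2 to compound 4 (0.30 log units; within the scatter).

The compounds shown do not separate the double bond from the ring with its hetero atom as the source of the gap to compound 1. From the compounds shown here alone, it also stays open whether a fully saturated chain carrying the same ring, a longer chain, or an amide in place of the chain amine would keep such a number.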